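Secondary versus tertiary benzylic amine in the bis(trifluoromethyl) sulfonamide series

A few compounds are considered here, and "the series" means these few. Any claim that something is new, unique, unknown or untested is made for them only; others in the source may bear on it.

Measured so far:
compound 1 `O=S(=O)(NCCCNCc1ccc(Cl)c(C(F)(F)F)c1)c1cc(C(F)(F)F)cc(C(F)(F)F)c1`: 5900 nM
compound 2 `CN(CCCNS(=O)(=O)c1cc(C(F)(F)F)cc(C(F)(F)F)c1)Cc1ccccc1`: 28000 nM

Going by the values given here, in a functional assay on A2780 cells (Homo sapiens) for inhibition, read by MTT assay, with a stated time of 72 h (on this read-out lower numbers stand for stronger inhibition of growth and higher numbers for weaker inhibition of growth), compound 2 gives 28000 nM, the higher of the two numbers known; compound 1 gives 5900 nM, a gap that lies beyond the usual scatter. Compound 3 `O=S(=O)(NCCCNCc1ccc(Br)cc1)c1cc(C(F)(F)F)cc(C(F)(F)F)c1` is not yet measured. It differs from compound 2 in one place: (4-bromobenzyl)amino in place of benzyl(methyl)amino on a saturated chain carbon, three bonds along the chain from a sulfonamide nitrogen. The step from compound 2 to compound 3 thus turns a tertiary benzylic amine into a secondary one and puts a bromine on the benzyl ring, which moves the compound toward the secondary-amine pattern of compound 1. Among the compounds with values here, no directly comparable step between measured compounds exists, so the expectation rests on compound 1 and compound 2 alone. A downward step of a 3.5-fold lower number from compound 2 to compound 3 (0.54 log units; beyond the scatter) is expected in this assay, beyond the scatter. Compound 3 is accordingly estimated at 8000 nM, within a range of 3000 nM to 25000 nM.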

Compound 3, concentration for 50% growth inhibition: 2600 nM
For compound 3 the middle estimate is 3.1-fold (0.49 log units) above the measured one; measured number outside the range, below it.
By their numbers in this assay, from the lowest: compound 3; then compound 1; then compound 2.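

In this assay, (4-bromobenzyl)amino in place of benzyl(methyl)amino gives an 11-fold lower number from compound 2 to compound 3 (1.03 log units; beyond the scatter) at this position, a large step beyond the scatter. This single exchange both removes the methyl group from the amine and adds bromine to the benzyl ring, so the two changes are read here only together. With the secondary amine kept, 4-bromophenyl in place of 4-chloro-3-(trifluoromethyl)phenyl gives a 2.3-fold lower number from compound 1 to compound 3 (0.36 log units; beyond the scatter) as a modest step, showing that the substitution on the benzyl ring alone moves the number. No evidence on the cause of either step is available.

A benzylamino or a (4-bromobenzyl)(methyl)amino group at this place would separate the contributions of the methyl group and the bromine. Going by these compounds, the effect of a longer chain between the sulfonamide nitrogen and the amine remains open.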